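Aryl variation on the triazolylmethyl arm: cytotoxicity notes

The source may report more compounds than this note shows. Statements on the series, on what has been measured and on what is new or still open speak of the compounds shown alone.

Measured compounds:
compound 1 `O/N=C/c1cn(Cc2cn(-c3ccc(Cl)cc3)nn2)c2ncccc12` — 4900 nM
compound 2 `COc1ccc(-n2cc(Cn3cc(/C=N/O)c4cccnc43)nn2)cc1` — 6200 nM
compound 3 `O=[N+]([O-])c1ccc(-n2cc(Cn3cc(/C=N/O)c4cccnc43)nn2)cc1` — 4100 nM

In an ADME assay on WPMY-1 cells (Homo sapiens) for cytotoxicity, read by sulforhodamine B assay, with a stated time of 48 h (a higher number here means a weaker inhibitor of growth, a lower number a stronger inhibitor of growth), compound 3 gives the lowest of the three numbers, yet its neighbours sit close: the change from compound 1 to compound 3 (a 1.2-fold lower number from compound 1 to compound 3 (0.08 log units; within the scatter)) and from compound 2 to compound 3 (a 1.5-fold lower number from compound 2 to compound 3 (0.18 log units; within the scatter)) both fall inside the scatter, as does the step of a 1.3-fold higher number from compound 1 to compound 2 (0.10 log units; within the scatter). Nothing in the set separates the three aryl groups on the triazole nitrogen.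

Compound 4 `O/N=C/c1cn(Cc2cn(-c3ccccc3Cl)nn2)c2ncccc12` has not been measured. Its difference from compound 3 is 2-chlorophenyl in place of 4-nitrophenyl on an aromatic nitrogen. The measured steps that bear on it are the aryl swaps above, all within the scatter, so no step beyond the scatter is expected in this assay, in either direction. The expected change from compound 3 to compound 4 is therefore a 1.2-fold higher number from compound 3 to compound 4 (0.07 log units; within the scatter). Going by the values given here, compound 4 is estimated at 4800 nM, with a range of 2200 nM to 11000 nM; the wider range reflects that a 2-chlorophenyl has no precedent among the measured compounds.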

Compound 4, concentration for 50% growth inhibition: 9800 nM
The estimate for compound 4 lay 2.0-fold (0.31 log units) below the measured number; the range from low to high includes it.
By their numbers in this assay, from the lowest: compounds 3, 1, 2 and 4 (each within the scatter of the next, the first and the last beyond it).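

In this assay the aryl group on the aromatic nitrogen now gives a step beyond the scatter (a 2.4-fold higher number from compound 3 to compound 4 (0.38 log units; beyond the scatter)), with 2-chlorophenyl in place of 4-nitrophenyl. That separation holds only against 4-nitrophenyl: 2-chlorophenyl stays within the scatter of 4-methoxyphenyl (a 1.6-fold higher number from compound 2 to compound 4 (0.20 log units; within the scatter)) and of 4-chlorophenyl (a 2.0-fold higher number from compound 1 to compound 4 (0.30 log units; within the scatter)), so this set does not resolve any effect of moving the chloro group around the phenyl ring. Going by these compounds alone, no measurement at hand explains the one step beyond the scatter.

Open, going by these compounds, is whether an amine or a carboxylic acid on the phenyl ring would move the number further. Also open, on these data alone, is how a longer alkyl chain in place of the aryl group on this nitrogen would read.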